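A Nitrile in Place of the Acetamide on the Core

The source may report more compounds than this note shows. Statements on the series, on what has been measured and on what is new or still open speak of the compounds shown alone.

This account follows a single change made on a shared saturated core. Compound 1 `CC(=O)NC12CCCC3CC(CCC31)C2` is the parent here; in an ADME assay (Gallus gallus) for cytotoxicity, read by microscopy, with a stated time of 24 h (on this read-out higher numbers stand for lower toxicity in this test and lower numbers for higher toxicity in this test), compound 1 gives 3000000 nM. Going by the values given here, the only other compound with a number is compound 3 `CCCCCCCCOC(=O)C12CCCC3CC(CCC31)C2`, which in this assay gives 490000 nM. In this assay compound 2 `C1=C2CCCC3CC1CCC23` gives no result reported. On the two numbers that exist, compound 1 stands highest, and its gap to compound 3 lies beyond the usual scatter of this measurement.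

The compound to be measured is compound 4 `N#CC12CCCC3CC(CCC31)C2`. It differs from compound 1 in one place: cyano in place of acetamido on a saturated ring carbon. Among the compounds with values here, no step between two measured compounds resembles this change, so there is no measured guide for the size of its effect. The two compounds with numbers differ in a different way, so what they show cannot be carried over directly.

The move from compound 1 to compound 4 is expected to give a step of a 2.0-fold lower number from compound 1 to compound 4 (0.30 log units; within the scatter), that is, a modestly lower number, but one that may well fall inside the scatter. In this assay compound 4 is therefore estimated at 1500000 nM, with a range from 400000 nM to 4000000 nM.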

Compound 4, minimum cytotoxic concentration: 850000 nM
Compound 4: middle estimate off by 1.8-fold (0.25 log units), on the high side; the measured number falls inside the stated range.
By their numbers in this assay, from the lowest: compounds 3 and 4 (each within the scatter of the next); then compound 1.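

In this assay, going by these compounds alone, the change gives a 3.5-fold lower number from compound 1 to compound 4 (0.55 log units; beyond the scatter), the first step in this set that isolates a single change on this saturated ring carbon. It shows that the number is sensitive to the group at this position: replacing acetamido, with its 4 heavy atoms and 1 hydrogen-bond donor, by cyano, with 2 heavy atoms and 0 hydrogen-bond donors, moves the number beyond the scatter, although the step remains modest. No measurement given here bears on why the number moves.

The compounds shown leave open whether another group at this position, such as an amine, a carboxylic acid or a simple alkyl chain, would give a number closer to that of compound 1 or further from it. Within the data shown here, they also leave open whether the change from acetamido to cyano would give a step of similar size on a different core, as this single pair is the only reading of that change.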